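Swapping 3-Methylphenyl for 4-Chlorophenyl: What to Expect

A few compounds are considered here, and "the series" means these few. Any claim that something is new, unique, unknown or untested is made for them only; others in the source may bear on it.

Among the compounds with values here, compound 2 `Cc1cccc(-n2cc(-c3ccccc3NS(=O)(=O)c3c[nH]c(=O)[nH]c3=O)nn2)c1` has the lower of the two numbers so far in a functional assay on HepG2 cells (Homo sapiens) for antiproliferative activity, read by MTT assay, with a stated time of 24 h (a higher number here means a weaker inhibitor, a lower number a stronger inhibitor), where compound 2 gives 3620 nM. In this assay compound 1 `O=c1[nH]cc(S(=O)(=O)Nc2ccccc2-c2cn(-c3ccccc3)nn2)c(=O)[nH]1` gives 6160 nM, and the step from compound 1 to compound 2, methyl in place of hydrogen on an aromatic carbon, is a 1.7-fold lower number from compound 1 to compound 2 (0.23 log units; within the scatter), so the two compounds cannot be ordered. Compound 3 `O=c1[nH]cc(S(=O)(=O)Nc2ccccc2-c2cn(-c3ccc(Cl)cc3)nn2)c(=O)[nH]1` differs from compound 2 by 4-chlorophenyl in place of 3-methylphenyl on an aromatic nitrogen. Within the data shown here, no measured step exchanges one substituted phenyl for another; the only measured step, a 1.7-fold lower number from compound 1 to compound 2 (0.23 log units; within the scatter), concerns the same phenyl and stays within the scatter. Compound 3 is therefore expected to land close to compound 2, with an expected step of a 1.1-fold higher number from compound 2 to compound 3 (0.04 log units; within the scatter), in no direction beyond the scatter. The estimate for compound 3 in this assay is 4000 nM, expected to fall between 1500 nM and 11000 nM.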

Compound 3, half-maximal inhibitory concentration: 1840 nM
Beside the measured number, compound 3's estimate is 2.2-fold (0.34 log units) above it; low and high end bracket the measured number.
By their numbers in this assay, from the lowest: compounds 3, 2 and 1 (each within the scatter of the next, the first and the last beyond it).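

In this assay a change on the phenyl carried by the aromatic nitrogen now gives a step beyond the scatter: adding a chloro to that phenyl is a 3.3-fold lower number from compound 1 to compound 3 (0.52 log units; beyond the scatter) and counts as a modest step, which the earlier methyl step did not reach. Exchanging one substituted phenyl for the other, the kind of change not measured before, gives a 2.0-fold lower number from compound 2 to compound 3 (0.29 log units; within the scatter) and stays within the scatter, so 4-chlorophenyl and 3-methylphenyl cannot be ordered at this position. Nothing available gives a reason for the step to the chloro compound.

The three compounds leave open whether chloro elsewhere on the phenyl would give a step of similar size. They also leave open how this assay would respond to an amine or a carboxylic acid on that phenyl.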